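A few compounds are considered here, and "the series" means these few. Any claim that something is new, unique, unknown or untested is made for them only; others in the source may bear on it.

Working notes on the series. Within the data shown here, compound 1 `COCC(=O)N(Cc1ccc(OC)c(O)c1)c1cc(OC)c(OC)c(OC)c1` carries an acyl group on the amide-type nitrogen together with a substituted benzyl group; in a functional assay on HCT-116 cells (Homo sapiens) for inhibition, read by MTT assay, with a stated time of 48 h (a lower number here means a stronger inhibitor, a higher number a weaker inhibitor), compound 1 gives 230 nM, the lowest of the two numbers measured so far. Compound 3 `C/C=C/C(=O)N(Cc1cccc(O)c1)c1cc(OC)c(OC)c(OC)c1`, with a different acyl group and a different benzyl group, gives 6700 nM in this assay; the gap between compound 1 and compound 3 lies beyond the scatter. Compound 2 `COc1cc(NCc2ccc(Cl)cc2)cc(OC)c1OC` has no acyl group on the nitrogen. For compound 2 this assay reports only a limit, > 80000 nM, which is the limit of > 80000 nM in this assay, at which 1 of the 3 values shown sits. Among the measured compounds shown here, no two measured compounds differ in a single place, so no measured step is available.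

Compound 4 `C=CC(=O)N(Cc1ccc(OC)c(O)c1)c1cc(OC)c(OC)c(OC)c1` differs from compound 1 by vinyl in place of methoxymethyl on a carbonyl carbon. The acyl group on the nitrogen is kept in compound 4, and compound 3 shows that an unsaturated acyl group can sit there with a measurable number, though its benzyl group also differs, so no direction can be read from it alone. The step of a 1.5-fold lower number from compound 1 to compound 4 (0.19 log units; within the scatter) is expected to stay within the scatter or to be a small gain. Compound 4 is estimated at 150 nM, with a range from 40 nM to 600 nM.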

Compound 4, half-maximal inhibitory concentration: 98 nM
Estimate against measurement, compound 4: 1.5-fold (0.18 log units) above; the range from low to high includes it.
By their numbers in this assay, from the lowest: compound 4; then compound 1; then compound 3. At a limit, above all of these: compound 2.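

Among these compounds, the first measured step falls on a carbonyl carbon whose other neighbour is the amide-type nitrogen: in this assay the change gives a 2.3-fold lower number from compound 1 to compound 4 (0.37 log units; beyond the scatter) with the rest of the structure unchanged. This shows that the number responds to the acyl group alone, which compound 3 could not show, since both its acyl group and its benzyl group differ from those of compound 1. It also shows that methoxymethyl is not required at this place, although no measured property in the series bears on why vinyl gives the lower number.

The compounds shown leave open whether the double bond or the loss of the ether oxygen accounts for the step, a question that an ethyl group on the same carbonyl carbon would address. They also leave open how an aminomethyl group or a longer chain would fare at this place, and whether the step would hold with the benzyl group of compound 3.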